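Anilide series: adding chloro to the pendant phenyl

The source may hold more compounds than are shown below. What is called first, only, known or untested is meant among the compounds shown, and "the series" means these compounds.

Measured so far, in a functional assay on HCT-116 cells (Homo sapiens) for cytotoxicity, read by MTT assay, with a stated time of 48 h; a lower number here means a stronger inhibitor, a higher number a weaker inhibitor:
compound 1 `O=C(Nc1ccc(Cl)cc1)c1cn(-c2ccccc2)nc1-c1ccccc1` gives 3520 nM
compound 2 `O=C(Nc1ccc(Br)cc1)c1cn(-c2ccccc2)nc1-c1ccccc1` gives 4470 nM
compound 3 `CCOc1ccc(NC(=O)c2cn(-c3ccccc3)nc2-c2ccccc2)cc1` gives 620 nM

Compound 1 stands second highest of the three numbers in this assay. Its nearest neighbour is compound 2, where a 1.3-fold higher number from compound 1 to compound 2 (0.10 log units; within the scatter). The furthest is compound 3, where a 5.7-fold lower number from compound 1 to compound 3 (0.75 log units; beyond the scatter); the step of a 7.2-fold lower number from compound 2 to compound 3 (0.86 log units; beyond the scatter) points the same way.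

Compound 4 `O=C(Nc1ccc(Cl)cc1)c1cn(-c2ccccc2)nc1-c1ccc(Cl)cc1` differs from compound 1 only by chloro in place of hydrogen on an aromatic carbon. Going by the values given here, all three measured steps alter the substituent on the anilide ring, whereas this change sits on the other six-membered aromatic ring of carbon only; none of them bears directly on it, and no measured pair shows what a chloro on that ring does. With no guide in either direction, the step from compound 1 to compound 4 is expected to be small, likely within the scatter, so the estimate for compound 4 is 3200 nM with a range of 1300 nM to 8000 nM, meaning an expected step of a 1.1-fold lower number from compound 1 to compound 4 (0.04 log units; within the scatter).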

Compound 4, half-maximal inhibitory concentration: 2990 nM
For compound 4 the middle estimate is 1.1-fold (0.03 log units) above the measured one, within the range that was stated.
By their numbers in this assay, from the lowest: compound 3; then compounds 4, 1 and 2 (each within the scatter of the next).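

The move from phenyl to 4-chlorophenyl on this ring, para to a large group, gives a 1.2-fold lower number from compound 1 to compound 4 (0.07 log units; within the scatter) in this assay. Going by these compounds alone, this is the first reading at this position: the earlier steps all changed the anilide substituent, and here a chloro enters on the other ring with a step that stays within the scatter. A chloro at this place is therefore compatible with a value in the same range as compound 1, though this rests on one pair. No supporting evidence bears on this result.

As far as these compounds go, whether the same chloro gives a similar step on the ethoxy anilide of compound 3 remains open. Also open, from the compounds shown here alone, is how a more different group at this position, such as an amine or a carboxylic acid, would read in this assay.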